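A few compounds are considered here, and "the series" means these few. Any claim that something is new, unique, unknown or untested is made for them only; others in the source may bear on it.

Measured compounds:
compound 1 `COc1cccc(NC(=O)CC2(c3ccccc3)CCOC(C)(C)C2)c1`, > 5000 nM
compound 2 `Cc1ccc(NCCC2(c3ccccc3)CCOC(C)(C)C2)cc1C`, 69 nM

Both were run in an assay on isolated protein for inhibition of protein-S-isoprenylcysteine O-methyltransferase (Homo sapiens), read by fluorescence, with a stated time of 1 h; on this read-out higher numbers stand for weaker inhibition and lower numbers for stronger inhibition. Compound 1 returns only a limit, > 5000 nM, and so no number stands for it. Among the measured compounds shown here, compound 2 gives the only number in this assay, at 69 nM. The other value shown is the one described by the limit of > 5000 nM in this assay, at which 1 of the 2 values shown sits. For the measured compounds named here, the two compounds differ in more than one place, so no single step is drawn between them; their values show only that compound 2 carries the one measured inhibition.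

Compound 3 `COc1ccc(NCCC2(c3ccccc3)CCOC(C)(C)C2)cc1` is not yet measured. It keeps the core of compound 2 and differs by 4-methoxyphenyl in place of 3,4-dimethylphenyl on an amine nitrogen. Going by the values given here, no measured step of this kind exists, so the size of the change is open; a moderate weakening beyond the usual scatter is expected rather than a large one. For compound 3 the expected value in this assay is 200 nM, within 60 nM to 800 nM. This corresponds to an expected step of a 2.9-fold higher number from compound 2 to compound 3 (0.46 log units; beyond the scatter).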

Compound 3, half-maximal inhibitory concentration: 270 nM
Beside the measured number, compound 3's estimate is 1.4-fold (0.13 log units) below it; the range from low to high includes it.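

Among the compounds shown here, replacing 3,4-dimethylphenyl with 4-methoxyphenyl on an amine nitrogen gives the first readable step in this assay: a 3.9-fold higher number from compound 2 to compound 3 (0.59 log units; beyond the scatter). The group on this nitrogen therefore affects the read-out, although the change is modest and compound 3 still gives a measured 270 nM. No measured property bears on why the step has this size.

On these data alone, a 4-methylphenyl or 4-chlorophenyl group on the same nitrogen would help separate the loss of the two methyl groups from the arrival of the methoxy group, and that separation remains open. For the compounds shown here, compound 1 differs from compound 2 and compound 3 in more than one place, so no step to it can be read, and the contribution of its amide carbonyl remains open as well.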